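Substituent change on the aryl ring of compound 1

The source may report more compounds than this note shows. Statements on the series, on what has been measured and on what is new or still open speak of the compounds shown alone.

Measured compounds:
compound 1 `COC(=O)C1=C(C)N=C(C)/C(=C(\O)OC)C1c1ccccc1N` — 39800 nM
compound 2 `COC(=O)C1=C(C)N=C(C)/C(=C(\O)OC)C1c1ccc(I)cc1` — 22900 nM
compound 3 `COC(=O)C1=C(C)N=C(C)/C(=C(\O)OC)C1c1ccccc1C#N` — 15.9 nM

In a functional assay (muscle tissue) with Cavia porcellus as the target (on this read-out lower numbers stand for an effect already at smaller amounts and higher numbers for an effect only at larger amounts of compound), compound 1 gives the highest of the three numbers; compound 2 sits within the scatter of it (a 1.7-fold lower number from compound 1 to compound 2 (0.24 log units; within the scatter)), whereas compound 3 is far off (a 2500-fold lower number from compound 1 to compound 3 (3.40 log units; beyond the scatter)). Compound 4 `COC(=O)C1=C(C)N=C(C)/C(=C(\O)OC)C1c1ccccc1F` differs from compound 1 by fluoro in place of amino on an aromatic carbon. Among the compounds with values here, the step that bears on this is the one from compound 1 to compound 3, where another replacement of the same amino group on the same aromatic carbon gave a very large lowering; the step from compound 1 to compound 2 is within the scatter and concerns a different ring position. A large lowering is therefore expected for compound 4 as well, a 400-fold lower number from compound 1 to compound 4 (2.60 log units; beyond the scatter), though with wide uncertainty. Compound 4 is estimated at 100 nM (range 15 nM to 800 nM).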

Compound 4, half-maximal effective concentration: 42.7 nM
For compound 4 the middle estimate is 2.3-fold (0.37 log units) above the measured one; the measured number falls inside the stated range.
By their numbers in this assay, from the lowest: compound 3; then compound 4; then compounds 2 and 1 (each within the scatter of the next).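

In this assay, a second replacement of the amino group on this aromatic carbon also gives a large lowering (a 930-fold lower number from compound 1 to compound 4 (2.97 log units; beyond the scatter)), so the drop is not peculiar to the nitrile of compound 3. Fluoro nevertheless remains modestly apart from cyano at this place (a 2.7-fold higher number from compound 3 to compound 4 (0.43 log units; beyond the scatter)), while the 2-fluorophenyl and 4-iodophenyl groups lie far apart (a 540-fold lower number from compound 2 to compound 4 (2.73 log units; beyond the scatter)). No measurement at hand accounts for these differences. From the compounds shown here alone, how a methyl, methoxy or chloro group on the same aromatic carbon would read remains open, as does the effect of fluoro elsewhere on the ring.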